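The compounds below may be only part of what the source reports. "The series", "measured", "known", "first", "only" and "open" are said of these compounds alone.

Compound 1 `O=S(=O)(c1cccc(-c2ccc3nccc(-c4ccncc4)c3n2)c1)N1CCC(O)CC1`: in an ADME assay on CHO cells (Cricetulus griseus) for cytotoxicity, read by MTT assay (a higher number here means a weaker inhibitor, a lower number a stronger inhibitor), compound 1 gives 8000 nM.
Compound 2 `O=S(=O)(NCCO)c1cccc(Nc2ccc3nccc(-c4ccncc4)c3n2)c1`: in this assay compound 2 gives 4000 nM.
Compound 3 `O=S(=O)(NCC1COC1)c1cccc(-c2ccc3nccc(-c4ccncc4)c3n2)c1`: in this assay compound 3 gives 16000 nM.

All three compounds share the same core and differ only in the group carried on the sulfonyl sulfur or in the link to the core. Compound 1 stands second highest of the three numbers; its nearest neighbour is compound 2, its furthest compound 3, and both lie within the scatter of it, so no order among the three can be claimed.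

The unmeasured compound 4 `O=S(=O)(CCO)c1cccc(-c2ccc3nccc(-c4ccncc4)c3n2)c1` is reached from compound 1 by one change:

2-hydroxyethyl in place of 4-hydroxypiperidin-1-yl on a sulfonyl sulfur

Among the measured compounds shown here, the one measured step that touches the same place, a 2.0-fold higher number from compound 1 to compound 3 (0.30 log units; within the scatter), exchanged the group on the sulfonyl sulfur and stayed within the scatter. A swap at the same position that keeps one hydrogen-bond donor and one hydrogen-bond acceptor is therefore expected to move the number little, if at all, and compound 4 is expected to show no change at the digits printed from compound 1 to compound 4 (within the scatter).

For compound 4 in this assay the estimated value is 8000 nM, expected to fall between 3000 nM and 20000 nM.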

Compound 4, half-maximal inhibitory concentration: 26000 nM
Estimate against measurement, compound 4: 3.3-fold (0.51 log units) below; the whole stated range lies below it.
By their numbers in this assay, from the lowest: compounds 2, 1, 3 and 4 (each within the scatter of the next, the first and the last beyond it).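

In this assay, 2-hydroxyethyl in place of 4-hydroxypiperidin-1-yl on the sulfonyl sulfur gives a 3.3-fold higher number from compound 1 to compound 4 (0.51 log units; beyond the scatter). Among the compounds shown here, this is the first step at this position that lies beyond the scatter, so the group here can move the number even when the count of hydrogen-bond donors and acceptors stays the same. The other new step, a 1.6-fold higher number from compound 3 to compound 4 (0.21 log units; within the scatter), lies within the scatter, so this assay does not separate 2-hydroxyethyl from ((oxetan-3-yl)methyl)amino; nothing measured here explains either step.

The group that leaves has a ring and a nitrogen, while the one that enters has neither, and the compounds shown do not say which of these differences matters. A piperidin-1-yl ring without its hydroxyl, or a longer chain such as 3-hydroxypropyl, on the sulfonyl sulfur would remain to be compared.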